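Methyl for methylsulfonyl on the amide nitrogen of compound 2

This account rests on a few compounds, and the source may have more. Where it says the series, first, only, none or still open, it means among the compounds named here.

Three compounds on one shared core were tested in an assay on isolated protein for inhibition of 2-Hydroxyacid oxidase 2 (Homo sapiens), tested at 10 uM; a lower number here means a weaker effect, a higher number a stronger effect of the compound at the concentration tested. Compound 1 `Cc1n[nH]c(C(=O)O)c1Cc1ccc(-c2ccc(F)cc2)cc1` gives 25%, compound 3 `Cc1n[nH]c(C(=O)O)c1CCc1ccc(F)cc1` gives 16%, and compound 2 `Cc1n[nH]c(C(=O)NS(C)(=O)=O)c1Cc1cccc(-c2ccc(F)cc2)c1` gives 8%. The number for compound 2 is the lowest of the three: compound 3 sits within the scatter of it, while compound 1 lies beyond the scatter above it. Compound 4 `CNC(=O)c1[nH]nc(C)c1Cc1cccc(-c2ccc(F)cc2)c1` differs from compound 2 in one place: methyl in place of methylsulfonyl on an amide-type nitrogen. Among the compounds with values here, no pair of measured compounds covers this change, so nothing measured sets its size. The expected step from compound 2 to compound 4 is a number 2 percentage points higher from compound 2 to compound 4 (within the scatter), none beyond the scatter. Compound 4 is therefore estimated to give 10%, between 0% and 25%, in this assay.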

Compound 4, a percentage reported as inhibition, at one concentration (the size of the read-out at that concentration, not a potency): 19%
Compound 4: the middle estimate sits 9 percentage points below what was measured; the range from low to high includes it.
By their numbers in this assay, from the lowest: compounds 2, 3, 4 and 1 (each within the scatter of the next, the first and the last beyond it).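

In this assay, methyl in place of methylsulfonyl on the amide-type nitrogen gives a number 11 percentage points higher from compound 2 to compound 4 (beyond the scatter), a modest step. Within the data shown here, this is the first sign that the group on this nitrogen affects the read-out, and that methylsulfonyl is not required there for the effect seen with compound 4. Nothing available explains the step.

On these data alone, it remains open how an ethyl group or a longer chain on this nitrogen would compare with methyl. As far as these compounds go, it is also open how a carboxylic acid in place of the whole methylcarbamoyl group would read on the core of compound 4.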